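Aryl sulfanyl variation on the shared diamino core

A few compounds are considered here, and "the series" means these few. Any claim that something is new, unique, unknown or untested is made for them only; others in the source may bear on it.

Compound 3 `Nc1cc(N)c2nc(-c3ccccc3)c(Sc3ccc(Cl)c(Cl)c3)nc2c1` carries a (3,4-dichlorophenyl)sulfanyl group on the shared core. In a functional assay on MOLT-4 cells (Homo sapiens) for inhibition, read by sulforhodamine B assay, with a stated time of 48 h (a higher number here means a weaker inhibitor of growth, a lower number a stronger inhibitor of growth), compound 3 gives only a limit, < 100000 nM. Compound 1 `Nc1cc(N)c2nc(-c3ccccc3)c(Oc3ccc(Cl)c(Cl)c3)nc2c1`, with 3,4-dichlorophenoxy in that place, also returns a limit in this assay, < 100000 nM. Compound 2 `Nc1cc(N)c2nc(-c3ccccc3)c(NCc3ccc(F)cc3)nc2c1`, bearing (4-fluorobenzyl)amino, likewise stops at a limit in this assay, < 100000 nM. The steps a step that the two limits leave unreadable from compound 1 to compound 3, a step that the two limits leave unreadable from compound 1 to compound 2 and a step that the two limits leave unreadable from compound 2 to compound 3 therefore have no readable size, a consequence of the limit of < 100000 nM in this assay, at which 3 of the 3 values shown sit, and compound 3 cannot be placed above or below either of the other two.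

Compound 4 `Nc1cc(N)c2nc(-c3ccccc3)c(Sc3ccc(F)cc3)nc2c1` differs from compound 3 by 4-fluorophenyl in place of 3,4-dichlorophenyl on a sulfur. Within the data shown here, no measured step alters only the aryl on the sulfur; the closest neighbour in the set, compound 2 with its 4-fluorobenzyl group, connects to compound 3 through a step that the two limits leave unreadable from compound 2 to compound 3, which is unreadable. Nothing here supports a direction beyond the scatter. Compound 4 is expected near 30000 nM, within 3000 nM to 100000 nM, and the step that the limit leaves unreadable from compound 3 to compound 4 is expected to stay within the scatter, with a real chance that the assay again reports only a limit.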

Compound 4, concentration for total growth inhibition: < 100000 nM
Compound 4 was reported as a limit (the forecaster's own chance of this, stated with the estimate: 60%); the middle value lies beyond the limit too.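

No new step can be read: the steps linking compound 4 to compound 1, compound 2 and compound 3 all remain without a size, because each compound returns only a limit: the limit of < 100000 nM in this assay, at which 4 of the 4 values shown sit.

Still open, as far as these compounds go, is whether the group changed on the shared core across compound 1, compound 2, compound 3 and compound 4 affects growth inhibition in this assay at all.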